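Fluoro to acetyl in a cytotoxicity series

The compounds below may be only part of what the source reports. "The series", "measured", "known", "first", "only" and "open" are said of these compounds alone.

Measured in an ADME assay on HEK293 cells (Homo sapiens) for cytotoxicity, with a stated time of 6 h (a lower number here means that less compound is tolerated, a higher number that more compound is tolerated), each entry being a limit of the assay:
Compound 1 `CCNc1nc(N)nc2ccccc12`: > 25000 nM
Compound 2 `CCCCNc1nc(N)nc2cc(CO)ccc12`: > 18000 nM
Compound 3 `CCCCNc1nc(N)nc2ccc(F)cc12`: > 18000 nM

Compound 3 gives no number in this assay, only a limit. It stands at the limit of > 18000 nM in this assay, at which 2 of the 3 values shown sit. Compound 1 stands alone at the limit of > 25000 nM in this assay, at which 1 of the 3 values shown sits. Among the measured compounds shown here, no measured compound has yet given a number, so no measured step can be read from them.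

Compound 4 `CCCCNc1nc(N)nc2ccc(C(C)=O)cc12` keeps the shared core and carries acetyl in place of fluoro on an aromatic carbon. No change beyond the scatter is expected in this assay, in either direction, and the estimated step is a step that the limit leaves unreadable from compound 3 to compound 4. For compound 4 the expected value is 20000 nM, with an estimated range of 8000 nM to 50000 nM.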

Compound 4, half-maximal cytotoxic concentration: > 18000 nM
Compound 4 was reported as a limit; the forecaster's own chance of this, stated with the estimate: 75%; the middle value is on the limit's open side.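

Compound 3 and compound 4 are both reported only as limits, so no step can be read between them. The compounds shown leave open at what concentration any of them becomes cytotoxic in this assay.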